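This account rests on a few compounds, and the source may have more. Where it says the series, first, only, none or still open, it means among the compounds named here.

Measured compounds in an assay on isolated protein for inhibition of Nicotinamide phosphoribosyltransferase (Homo sapiens), read by WST assay, with stated times of 60 min, 5 min and 30 min, in the presence of a further agent that is not named here; a lower number here means a stronger inhibitor, a higher number a weaker inhibitor:
compound 1 `O=C(/C=C/c1cccnc1)NCCCCCCc1cccc(S(=O)(=O)Nc2ccccc2)c1` gives 10.5 nM
compound 2 `Cc1cccc(NS(=O)(=O)c2cccc(CCCCCCNC(=O)/C=C/c3cccnc3)c2)c1` gives 12.3 nM

Compound 2 carries the highest number of the two; the nearest is compound 1, and the step of a 1.2-fold higher number from compound 1 to compound 2 (0.07 log units; within the scatter) lies within the scatter. Compound 3 `Cc1ccc(C)c(NS(=O)(=O)c2cccc(CCCCCCNC(=O)/C=C/c3cccnc3)c2)c1` differs from compound 2 by methyl in place of hydrogen on an aromatic carbon. Within the data shown here, only one measured step bears on this change, a 1.2-fold higher number from compound 1 to compound 2 (0.07 log units; within the scatter), which added a methyl on the same aromatic ring without a step beyond the scatter. For the second methyl, ortho to a large group, the expectation is likewise no step beyond the scatter, a 1.2-fold higher number from compound 2 to compound 3 (0.09 log units; within the scatter). Compound 3 is therefore estimated at 15 nM, range 6 nM to 40 nM.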

Compound 3, half-maximal inhibitory concentration: 11.6 nM
Beside the measured number, compound 3's estimate is 1.3-fold (0.11 log units) above it, within the range that was stated.
By their numbers in this assay, from the lowest: compounds 1, 3 and 2 (each within the scatter of the next).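

In this assay the methyl ortho to a large group and para to a methyl group gives a 1.1-fold lower number from compound 2 to compound 3 (0.03 log units; within the scatter) and so adds no step beyond the scatter to the first methyl. Taken together, the 2,5-dimethylphenyl group gives a 1.1-fold higher number from compound 1 to compound 3 (0.04 log units; within the scatter) and shows that this ring carries both methyls within the scatter of the unsubstituted phenyl. No measurement at hand explains this flat response.

The compounds shown leave open whether this position also accepts anything other than methyl, such as a carboxylic acid, an amine or a tert-butyl group.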